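A few compounds are considered here, and "the series" means these few. Any claim that something is new, unique, unknown or untested is made for them only; others in the source may bear on it.

In an assay on HEK293 cells for displacement of a labelled ligand from Orexin receptor type 2 (Homo sapiens), read by scintillation counting, with a stated time of 90 min (on this read-out lower numbers stand for stronger inhibition and higher numbers for weaker inhibition), compound 3 `COc1ccc(N2C(=O)N(Cc3c(F)cc(F)cc3Cl)c3ccccc3S2(=O)=O)cc1OC` gives 1 nM. Of the three numbers recorded in this assay, that of compound 3 is the second highest. Its nearest neighbour is compound 1 `COc1ccc(N2C(=O)N(Cc3c(F)cc(F)cc3F)c3ccccc3S2(=O)=O)cc1OC`, which gives 2 nM; the step of a 2.0-fold lower number from compound 1 to compound 3 (0.30 log units; within the scatter) is within the scatter, so the two compounds cannot be told apart. The furthest is compound 2 `COc1cc(F)c(CN2C(=O)N(c3cnc(OC)c(OC)c3)S(=O)(=O)c3ccccc32)c(F)c1`, which gives 0.398 nM, a number lower than that of compound 3 by more than the scatter. For the measured compounds named here, compound 2 differs from compound 3 in two places at once, so no single step connects them.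

Compound 4 `COc1cc(N2C(=O)N(Cc3c(F)cc(F)cc3Cl)c3ccccc3S2(=O)=O)cnc1OC` changes compound 3 in one place: 5,6-dimethoxypyridin-3-yl in place of 3,4-dimethoxyphenyl on an amide-type nitrogen in a ring. Going by the values given here, no measured step covers exactly this change. Among the compounds with values here, the only step in this assay, from compound 1 to compound 3, concerns a different part of the molecule and lies within the scatter. Within the data shown here, the one compound that carries the dimethoxypyridine, compound 2, has the lowest number, but its other differences blur what that shows. The step of a 1.7-fold lower number from compound 3 to compound 4 (0.22 log units; within the scatter) is therefore expected to be small, if anything towards a lower number. Compound 4 is estimated at 0.6 nM, within a range from 0.2 nM to 2 nM.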

Compound 4, inhibition constant: 1.59 nM
Estimate against measurement, compound 4: 2.7-fold (0.42 log units) below, and the stated range covers the measured number.
By their numbers in this assay, from the lowest: compound 2; then compounds 3, 4 and 1 (each within the scatter of the next).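

In this assay the swap to 5,6-dimethoxypyridin-3-yl at this position gives a 1.6-fold higher number from compound 3 to compound 4 (0.20 log units; within the scatter) and so the ring nitrogen that enters leaves the two compounds indistinguishable on this read-out. For the compounds shown here, both compound 2 and compound 4 carry the dimethoxypyridine, and the single change between them gives a 4.0-fold higher number from compound 2 to compound 4 (0.60 log units; beyond the scatter) so the low number of compound 2 goes with its 2,6-difluoro-4-methoxyphenyl group and not with the pyridine alone. No supporting data here explain the size of either step.

The compounds shown do not tell whether the pyridine swap would also pass unnoticed alongside the 2,6-difluoro-4-methoxyphenyl group. Also open, as far as these compounds go, is how this position responds to an aryl ring carrying an amine or a carboxylic acid in place of a methoxy group.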